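Pyrazoline sulfonamides: arylvinyl versus aryl at the saturated carbon

This account rests on a few compounds, and the source may have more. Where it says the series, first, only, none or still open, it means among the compounds named here.

Measured so far:
compound 1 `Cc1cc(O)c(C2=NN(c3ccc(S(N)(=O)=O)cc3)C(c3ccccc3O)C2)cc1Cl` — 6560 nM
compound 2 `Cc1cc(O)c(C2=NN(c3ccc(S(N)(=O)=O)cc3)C(/C=C/c3ccccc3)C2)cc1Cl` — 44200 nM

In a functional assay on M14 cells (Homo sapiens) for antiproliferative activity, with a stated time of 48 h (a higher number here means that more compound is tolerated, a lower number that less compound is tolerated), compound 2 holds the highest of the two numbers; its nearest neighbour is compound 1, and the step of a 6.7-fold higher number from compound 1 to compound 2 (0.83 log units; beyond the scatter) lies beyond the scatter. Compound 3 `COc1ccc(C2CC(c3cc(Cl)c(C)cc3O)=NN2c2ccc(S(N)(=O)=O)cc2)cc1OC` is not yet measured. It differs from compound 2 in one place: 3,4-dimethoxyphenyl in place of 2-phenylethenyl on a saturated ring carbon. Within the data shown here, the only measured step that bears on this change is the one from compound 1 to compound 2, which replaced an aromatic ring directly on the saturated ring carbon by 2-phenylethenyl and raised the number by a 6.7-fold higher number from compound 1 to compound 2 (0.83 log units; beyond the scatter). Compound 3 reverses that type of change, putting an aromatic ring back on the saturated carbon, though 3,4-dimethoxyphenyl is not 2-hydroxyphenyl, so the return to the level of compound 1 is uncertain. Compound 3 is therefore expected to give a lower number than compound 2 in this assay, with the step of a 4.4-fold lower number from compound 2 to compound 3 (0.65 log units; beyond the scatter) estimated beyond the scatter. The estimate for compound 3 in this assay is 10000 nM, ranging from 3000 nM to 35000 nM.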

Compound 3, concentration lethal to 50% of the cells: 38300 nM
Compound 3: middle estimate off by 3.8-fold (0.58 log units), on the low side, and the stated range ends below it.
By their numbers in this assay, from the lowest: compound 1; then compounds 3 and 2 (each within the scatter of the next).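

In this assay the exchange of 2-phenylethenyl for 3,4-dimethoxyphenyl on the saturated ring carbon gives a 1.2-fold lower number from compound 2 to compound 3 (0.06 log units; within the scatter) and so separates the two groups by no more than the usual scatter. An aromatic ring attached directly at this position therefore does not by itself bring the number back to the level of compound 1, and the earlier step can no longer be read as a simple contrast between an aromatic ring and 2-phenylethenyl. Two directly attached aromatic rings instead differ by a 5.8-fold higher number from compound 1 to compound 3 (0.77 log units; beyond the scatter), so among these three compounds 2-hydroxyphenyl alone stands apart, with compound 1 lowest and its steps to both others beyond the scatter.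

From the compounds shown here alone, compounds 1 and 3 differ in the whole substitution of the ring, so these values cannot assign the separation to the hydroxyl group rather than to the absence of the two methoxy groups, and it remains open whether 2-aminophenyl, 2-methoxyphenyl or unsubstituted phenyl would fall with compound 1 or with compound 3. No measurement at hand accounts for the separation of compound 1 from the other two.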